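Cytotoxicity series: three quinolone esters measured, one expected

This account rests on a few compounds, and the source may have more. Where it says the series, first, only, none or still open, it means among the compounds named here.

Measured compounds and their values in an ADME assay on HEK293 cells (Homo sapiens) for cytotoxicity, read by luminescence, with a stated time of 72 h; a higher number here means that more compound is needed for the effect, a lower number that less compound is needed:
- compound 1, `CCOC(=O)c1c(-c2cccc(-c3ccccc3)c2)[nH]c2cc(OC)ccc2c1=O`: > 22000 nM
- compound 2, `CCOC(=O)c1c(-c2cccc(OCc3ccccc3)c2)[nH]c2cc(OC)ccc2c1=O`: > 22000 nM
- compound 3, `CCOC(=O)c1c(-c2cccc(C(F)(F)F)c2)[nH]c2cc(OC)ccc2c1=O`: > 22000 nM

Each of these values is a limit of this assay, not a number. For compound 1 the result > 22000 nM is such a limit. For compound 2 the result > 22000 nM is a limit as well. For compound 3 the result > 22000 nM is again a limit. Compound 2 therefore stands nowhere on a scale; it sits at the same ceiling as the other two, as the limit of > 22000 nM in this assay, at which 3 of the 3 values shown sit, records.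

The steps among the measured compounds, a step that the two limits leave unreadable from compound 1 to compound 2, a step that the two limits leave unreadable from compound 1 to compound 3 and a step that the two limits leave unreadable from compound 2 to compound 3, are all unreadable in size for this reason.

Compound 4, `CCOC(=O)c1c(-c2cccc(N(C)C)c2)[nH]c2cc(OC)ccc2c1=O`, is not yet measured. It differs from compound 2 as follows: dimethylamino in place of benzyloxy on an aromatic carbon. The measured steps that bear on it are those leaving or entering compound 2, and none of them gives a readable size. No step beyond the scatter can thus be expected in this assay in either direction. Compound 4 is expected at 30000 nM, with a range from 15000 nM to 100000 nM, most likely again as a limit. The step that the limit leaves unreadable from compound 2 to compound 4 is the expected one, estimated as essentially flat.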

Compound 4, half-maximal effective concentration: > 22000 nM
Compound 4 ended at the assay's limit; the forecaster's own chance of this, stated with the estimate: 80%; the middle value does not contradict the limit.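

No new step can be read from compound 4 to compound 1, compound 2 or compound 3, because all four compounds sit at one ceiling: the limit of > 22000 nM in this assay, at which 4 of the 4 values shown sit.

The compounds shown leave open whether phenyl, benzyloxy, trifluoromethyl and dimethylamino differ at all in this assay, and at what concentration any of the four reaches the half-maximal effect.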